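The compounds below may be only part of what the source reports. "The series", "measured", "known", "first", "only" and "open" are said of these compounds alone.

In an ADME assay on microsomes from liver (Homo sapiens) for metabolic stability, read by LC-MS, using NADPH, with a stated time of 10 min, tested at 0.5 uM (on this read-out lower numbers stand for a less stable compound and higher numbers for a more stable compound), compound 1 `COC(=O)Nc1cc(-c2ccc(OC[C@@](C)(N)CC(C)C)cn2)ccn1` gives 93% and compound 2 `COC(=O)Nc1cc(-c2cc(Cl)c(OC[C@@](C)(N)CC(C)C)cn2)ccn1` gives 96% in the same test. These two numbers lie within the scatter of each other, so no order can be read between them, and compound 2 simply stands alongside compound 1. Compound 3 `COC(=O)Nc1cc(-c2cc(C)c(OC[C@@](C)(N)CC(C)C)cn2)ccn1` differs from compound 2 at a single place: methyl in place of chloro on an aromatic carbon. For the measured compounds named here, the only measured step at this place, a number 3 percentage points higher from compound 1 to compound 2 (within the scatter) for chloro in place of hydrogen, is small, so no change beyond the scatter is expected for compound 3. Going by the values given here, no measured compound carries methyl there, which makes this a thin guide. The estimated change is a number 6 percentage points lower from compound 2 to compound 3 (within the scatter) and it is expected to stay within the scatter. For compound 3 the estimated value is 90% with an expected range from 78% to 99% in this test.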

Compound 3, percent of the compound remaining: 100%
Compound 3: middle estimate off by 10 percentage points, on the low side, and the stated range ends below it.
By their numbers in this assay, from the lowest: compounds 1, 2 and 3 (each within the scatter of the next).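

In this assay, this place, opposite the ring nitrogen, now carries three different groups: hydrogen, chloro and methyl. Swapping chloro for methyl gives a number 4 percentage points higher from compound 2 to compound 3 (within the scatter), and putting methyl where hydrogen stood gives a number 7 percentage points higher from compound 1 to compound 3 (within the scatter), so neither step separates the compounds, and a carbon group at this place reads the same as a halogen or hydrogen, with compound 3 at 100% leaving the read-out no room to go further. Nothing given here explains why these groups read alike.

As far as these compounds go, it remains open whether a bulkier or differently built group at this place, such as methoxy, trifluoromethyl or a longer chain, would also stay within the scatter. From the compounds shown here alone, with all three compounds so high on this scale, it is also open whether a harsher test would pull them apart.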